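Methyl on the Alcohol Oxygen: Compound 3 to Compound 4

The compounds below may be only part of what the source reports. "The series", "measured", "known", "first", "only" and "open" are said of these compounds alone.

Compound 3 `C=CC(=O)Nc1cccc(C(O)CCCC)c1` gives only a limit in a functional assay on MCF7 cells (Homo sapiens) for antiproliferative activity, with a stated time of 48 h (a lower number here means a stronger inhibitor, a higher number a weaker inhibitor), namely > 100000 nM. Compound 2 `CCCCC(OC)c1cccc(NC(=O)CCCCl)c1` likewise returns only a limit, > 100000 nM. Two of the three measured values therefore sit at the limit of > 100000 nM in this assay, at which 2 of the 3 values shown sit. Going by the values given here, compound 1 `CCCCC(OC)c1cccc(NC(=O)CCl)c1` gives a number, 12000 nM, and the single measured step, an at least 8.3-fold higher number from compound 1 to compound 2 (0.92 log units; beyond the scatter), concerns the chloroalkyl chain, not the oxygen on the saturated carbon. Compound 4 `C=CC(=O)Nc1cccc(C(CCCC)OC)c1` differs from compound 3 by methyl in place of hydrogen on an oxygen on a saturated carbon. Among the compounds with values here, no measured step bears on this change; compound 1 also carries the methoxy and still gives a weak number. Compound 4 is expected to move by an at least 1.6-fold lower number from compound 3 to compound 4 (0.22 log units; that floor lies within the scatter), nothing clearly beyond the scatter. Compound 4 is estimated at 60000 nM, within 15000 nM to 150000 nM.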

Compound 4, half-maximal inhibitory concentration: > 100000 nM
Compound 4: no number, only a limit; the forecaster's own chance of this, stated with the estimate: 55%; middle value at least 1.6-fold (0.22 log units) from the limit.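

Methyl in place of hydrogen on the oxygen brings nothing readable in this assay for the vinyl amide, since compound 4 returns a limit, and the steps to it from compound 3 and compound 2 cannot be read. Going by these compounds alone, with the methoxy kept, vinyl in place of chloromethyl on the carbonyl carbon gives an at least 8.3-fold higher number from compound 1 to compound 4 (0.92 log units; beyond the scatter) and so leaves compound 1 as the only compound with a number. The limit now holds most of the set: the limit of > 100000 nM in this assay, at which 3 of the 4 values shown sit.

From the compounds shown here alone, whether the free hydroxy would matter on the chloromethyl amide stays open. So does whether an amine on that saturated carbon would give a number.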